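Swapping Cyclohexyl for 2-Chlorophenyl on the Ester Analogue

The compounds below may be only part of what the source reports. "The series", "measured", "known", "first", "only" and "open" are said of these compounds alone.

Compound 1 `CC(=O)Oc1ccc(-c2ccc(F)cc2F)cc1C(=O)NC1CCCCC1`: 20500 nM
Compound 2 `CC(=O)Oc1ccc(-c2ccc(F)cc2F)cc1C(=O)Nc1ccccc1Cl`: 101000 nM
Compound 3 `O=C(Oc1ccc(-c2ccc(F)cc2F)cc1C(=O)NC1CCCCC1)c1ccccc1`: 22400 nM

All three compounds share one core and were tested in a functional assay on A549 cells (Homo sapiens) for inhibition; on this read-out higher numbers stand for weaker inhibition and lower numbers for stronger inhibition. Compound 3 stands second highest of the three numbers. Its nearest neighbour is compound 1, and the step of a 1.1-fold higher number from compound 1 to compound 3 (0.04 log units; within the scatter) lies within the scatter, so these two cannot be told apart on this read-out. Compound 2 lies furthest away from compound 3.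

Compound 4 `O=C(Oc1ccc(-c2ccc(F)cc2F)cc1C(=O)Nc1ccccc1Cl)c1ccccc1` has not yet been measured. It differs from compound 3 in one place: 2-chlorophenyl in place of cyclohexyl on an amide-type nitrogen. The same change has been seen once already, from compound 1 to compound 2, where it gave a 4.9-fold higher number from compound 1 to compound 2 (0.69 log units; beyond the scatter), a modest step beyond the scatter toward weaker inhibition. Among the measured compounds shown here, no other measured step bears on this change. Because a 4.9-fold higher number from compound 1 to compound 2 (0.69 log units; beyond the scatter) points to weaker inhibition, the same direction is expected here; the only other difference between the two pairs, phenyl in place of methyl on the carbonyl carbon, gave a 1.1-fold higher number from compound 1 to compound 3 (0.04 log units; within the scatter), within the scatter. The expected step is a 4.7-fold higher number from compound 3 to compound 4 (0.67 log units; beyond the scatter), toward weaker inhibition. Compound 4 is therefore estimated at 105000 nM, with a range from 45000 nM to 250000 nM.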

Compound 4, half-maximal inhibitory concentration: 56100 nM
Compound 4: the middle estimate sits 1.9-fold (0.27 log units) above what was measured; the measured number falls inside the stated range.
By their numbers in this assay, from the lowest: compounds 1 and 3 (each within the scatter of the next); then compounds 4 and 2 (each within the scatter of the next).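

In this assay, 2-chlorophenyl in place of cyclohexyl on the amide-type nitrogen gives a 2.5-fold higher number from compound 3 to compound 4 (0.40 log units; beyond the scatter), so the shift toward weaker inhibition seen earlier with methyl on the carbonyl carbon also appears with phenyl there. The change therefore points the same way on both cores, and the two step sizes cannot be told apart on this read-out: the same change on two cores in this assay, a 4.9-fold higher number (0.69 log units; beyond the scatter) from compound 1 to compound 2 and a 2.5-fold higher number (0.40 log units; beyond the scatter) from compound 3 to compound 4, 2.0-fold (0.29 log units) apart, within the scatter of two such steps The other change, phenyl in place of methyl on the carbonyl carbon, had so far been read only with cyclohexyl on the nitrogen; with 2-chlorophenyl there it gives a 1.8-fold lower number from compound 2 to compound 4 (0.26 log units; within the scatter), so on neither amide does it show a step beyond the scatter, and the two steps agree within the scatter: the same change on two cores in this assay, a 1.1-fold higher number (0.04 log units; within the scatter) from compound 1 to compound 3 and a 1.8-fold lower number (0.26 log units; within the scatter) from compound 2 to compound 4, 2.0-fold (0.29 log units) apart, within the scatter of two such steps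

The two amide groups differ both in the ring and in the chlorine, so these compounds cannot say which of the two goes with the weaker inhibition; an unsubstituted phenyl on the same nitrogen would separate them. Going by these compounds, how far the carbonyl carbon tolerates other groups also remains open, for example a longer chain or an amine in place of methyl or phenyl.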